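The compounds below may be only part of what the source reports. "The series", "measured", "known", "first", "only" and "open" are said of these compounds alone.

Three measured compounds share one core and differ only in the group that sits on an aromatic carbon. Compound 1 `O=C1NC(=O)/C(=C/c2ccc(OCCSc3nnc(-c4ccccc4)[nH]3)cc2)S1` carries a phenyl there, and in a functional assay on the whole organism (plasma, strain Wistar) with Rattus norvegicus as the target, with a stated time of 15 days, at a dose of 10 mg/kg by the oral route (a higher number here means a stronger effect of the compound at the dose given, a lower number a weaker effect), compound 1 gives 10.6%. Compound 2 `O=C1NC(=O)/C(=C/c2ccc(OCCSc3nnc(Cc4ccccc4)[nH]3)cc2)S1` carries a benzyl instead, and in this assay compound 2 gives 19.4%. Compound 3 `Cc1ccc(-c2nnc(SCCOc3ccc(/C=C4\SC(=O)NC4=O)cc3)[nH]2)cc1` carries a 4-methylphenyl, and in this assay compound 3 gives 20.4%. On the numbers shown, compound 3 stands at the top of the three, yet the gaps are small: a number 1 percentage points higher from compound 2 to compound 3 (within the scatter) and a number 9.8 percentage points higher from compound 1 to compound 3 (within the scatter), so all three readings sit within the scatter of one another, and none can be called the most active.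

Compound 4 `O=C1NC(=O)/C(=C/c2ccc(OCCSc3nnc(-c4ccc([N+](=O)[O-])cc4)[nH]3)cc2)S1` has not yet been measured. It differs from compound 3 in one place (nitro in place of methyl on an aromatic carbon). For the measured compounds named here, the only measured step that touches this same spot is a number 9.8 percentage points higher from compound 1 to compound 3 (within the scatter), and together with a number 8.8 percentage points higher from compound 1 to compound 2 (within the scatter) it shows that changing the group here has so far moved the reading by no more than the scatter. A step of similar size, in no particular direction, is therefore expected for a number 2.4 percentage points lower from compound 3 to compound 4 (within the scatter). Compound 4 is estimated at 18%, with a range from 4% to 32%.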

Compound 4, a percentage reported as activity, at one dose (the size of the read-out at that dose, not a potency): 13.9%
Beside the measured number, compound 4's estimate is 4.1 percentage points above it; the range from low to high includes it.
By their numbers in this assay, from the lowest: compounds 1, 4, 2 and 3 (each within the scatter of the next).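

The change from 4-methylphenyl to 4-nitrophenyl brings in two hydrogen-bond acceptors where the methyl had none, yet this assay shows a number 6.5 percentage points lower from compound 3 to compound 4 (within the scatter), so even this change of group gives no reading that stands apart. The other two comparisons agree, with a number 5.5 percentage points lower from compound 2 to compound 4 (within the scatter) and a number 3.3 percentage points higher from compound 1 to compound 4 (within the scatter). With nitro added, the position has now carried four different groups, and this assay still separates none of the four compounds from the others.

Nothing shown here accounts for the small differences among these readings. Going by these compounds, it remains open whether an amine or a carboxylic acid on this ring, or a longer chain in place of the benzyl, would give a reading clearly beyond the scatter of these four.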